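Swapping the outer aryl ring of a fatty acid receptor agonist

The source may report more compounds than this note shows. Statements on the series, on what has been measured and on what is new or still open speak of the compounds shown alone.

Measured so far:
compound 1 `COc1ccc(-c2cccc(COc3ccc([C@H](CC(=O)O)c4nccn4C)cc3)c2)cc1` gives 440 nM
compound 2 `Cc1cc(F)ccc1-c1cccc(COc2ccc([C@H](CC(=O)O)c3nccn3C)cc2)c1` gives 59 nM
compound 3 `Cc1c(Cl)cccc1-c1cccc(COc2ccc([C@H](CC(=O)O)c3nccn3C)cc2)c1` gives 61 nM

All three compounds share one core and differ only in the outer aryl ring. In an assay on CHO cells for agonist activity at Free fatty acid receptor 1 (Homo sapiens), read by luminescence, with a stated time of 20 s, in the presence of a further agent that is not named here (a lower number here means that less compound is needed, a higher number that more compound is needed for the effect), compound 1 gives the highest number of the three, so it needs the most compound for the effect. Its nearest neighbour is compound 3 a 7.2-fold lower number from compound 1 to compound 3 (0.86 log units; beyond the scatter) and the furthest is compound 2 a 7.5-fold lower number from compound 1 to compound 2 (0.87 log units; beyond the scatter); the two substituted rings sit close together a 1.0-fold higher number from compound 2 to compound 3 (0.01 log units; within the scatter).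

Compound 4 `Cc1ccccc1-c1cccc(COc2ccc([C@H](CC(=O)O)c3nccn3C)cc2)c1` has not yet been measured. It differs from compound 1 in one place: 2-methylphenyl in place of 4-methoxyphenyl on an aromatic carbon. The two steps that bear on this change both replace the 4-methoxyphenyl by a ring that carries a 2-methyl group together with a halogen, and both gave a modest drop in the number. Compound 4 keeps the 2-methyl group but carries no halogen, so a drop is expected, though perhaps a smaller one than in compounds 2 and 3. Compound 4 is therefore estimated at 110 nM, within a range of 45 nM to 280 nM, which corresponds to an expected step of a 4.0-fold lower number from compound 1 to compound 4 (0.60 log units; beyond the scatter).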

Compound 4, half-maximal effective concentration: 43 nM
Beside the measured number, compound 4's estimate is 2.6-fold (0.41 log units) above it; measured number outside the range, below it.
By their numbers in this assay, from the lowest: compounds 4, 2 and 3 (each within the scatter of the next); then compound 1.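

The halogens on compounds 2 and 3 turn out not to be needed in this assay: replacing the chloro with hydrogen gives no change beyond the scatter (a 1.4-fold lower number from compound 3 to compound 4 (0.15 log units; within the scatter)), and neither does replacing the fluoro with hydrogen (a 1.4-fold lower number from compound 2 to compound 4 (0.14 log units; within the scatter)). The 2-methylphenyl ring with no halogen is therefore enough for the full step away from the 4-methoxyphenyl ring (a 10-fold lower number from compound 1 to compound 4 (1.01 log units; beyond the scatter)), which now counts as large rather than modest, and compounds 2, 3 and 4 cannot be told apart in this assay. For the compounds shown here, nothing available here explains why the swap of rings moves the number so far.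

The step from compound 1 to compound 4 makes two changes at once, adding the 2-methyl group and removing the 4-methoxy group, so these compounds cannot show which one matters, or whether both do. A plain phenyl ring and a 4-methoxy-2-methylphenyl ring would separate the two changes, while a 2-ethylphenyl or 2-chlorophenyl ring would test how specific the need for the methyl group is.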